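This account rests on a few compounds, and the source may have more. Where it says the series, first, only, none or still open, it means among the compounds named here.

Compound 3, `COc1cc(NC(=O)Nc2cc(Nc3ccc(C)c(F)c3)ncn2)cc(OC)c1`, is the middle member of a small set of three ureas that share one core and differ only in the aryl group attached to the ring nitrogen. In a functional assay on NCI-H1581 cells (Homo sapiens) for inhibition, read by MTT assay, with a stated time of 48 h, tested at 10 uM (a higher number here means more inhibition at the concentration tested (going by the name of the read-out), a lower number less inhibition), compound 3 gives 38%. Compound 1, `COc1cc(NC(=O)Nc2cc(Nc3cccc(C(C)(C)C)c3)ncn2)cc(OC)c1`, gives 35.1%, and compound 2, `COc1cc(NC(=O)Nc2cc(Nc3ccc(F)c(Cl)c3)ncn2)cc(OC)c1`, gives 53%; the step of a number 15 percentage points lower from compound 2 to compound 3 (beyond the scatter) shows the only difference beyond the scatter, while a number 2.9 percentage points higher from compound 1 to compound 3 (within the scatter) does not.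

Compound 4, `COc1cc(NC(=O)Nc2cc(Nc3cc(F)ccc3OC)ncn2)cc(OC)c1`, carries a different aryl group: 5-fluoro-2-methoxyphenyl in place of 3-fluoro-4-methylphenyl on a nitrogen on an aromatic ring. Within the data shown here, no measured step introduces a methoxy group, so the change is untested. The steps of a number 17.9 percentage points higher from compound 1 to compound 2 (beyond the scatter) and a number 2.9 percentage points higher from compound 1 to compound 3 (within the scatter) show that swapping the aryl substituents moved the result by a modest amount at most. A step within the scatter is therefore expected, a number 2 percentage points higher from compound 3 to compound 4 (within the scatter). For compound 4 the estimate is 40%, between 22% and 58%.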

Compound 4, a percentage reported as inhibition, at one concentration (the size of the read-out at that concentration, not a potency): 42.1%
Compound 4: the middle estimate sits 2.1 percentage points below what was measured; the range from low to high includes it.
By their numbers in this assay, from the lowest: compounds 1, 3 and 4 (each within the scatter of the next); then compound 2.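

Replacing 3-fluoro-4-methylphenyl with 5-fluoro-2-methoxyphenyl brings an oxygen and a hydrogen-bond acceptor to this position, yet the result in this assay stays level with compound 3 (a number 4.1 percentage points higher from compound 3 to compound 4 (within the scatter)) and with compound 1 (a number 7 percentage points higher from compound 1 to compound 4 (within the scatter)). Only the 3-chloro-4-fluorophenyl group of compound 2 stands apart (a number 10.9 percentage points lower from compound 2 to compound 4 (beyond the scatter)). Nothing available here explains these differences.

Still open, going by these compounds, is whether the methoxy group or the altered fluorine placement matters more. Also open, on these data alone, is how an aryl group bearing an amine or a carboxylic acid would behave at this position.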